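This account rests on a few compounds, and the source may have more. Where it says the series, first, only, none or still open, it means among the compounds named here.

Of the compounds shown here, three built on one shared core have been measured in a functional assay on SK-MEL-28 cells (Homo sapiens) for cytotoxicity, read by MTT assay; a higher number here means a weaker inhibitor, a lower number a stronger inhibitor. Compound 1 `Cc1ccc(S(=O)(=O)NCCCNc2nccc(-c3c(-c4cccc(F)c4)nc4sccn34)n2)cc1` gives 9500 nM. Compound 2 `O=S(=O)(NCCCNc1nccc(-c2c(-c3cccc(F)c3)nc3sccn23)n1)c1ccccc1` gives 6850 nM. Compound 3 `O=S(=O)(NCCNc1nccc(-c2c(-c3cccc(F)c3)nc3sccn23)n1)c1ccc(Cl)cc1` gives 18600 nM. Of these three numbers compound 2 has the lowest; the step of a 1.4-fold lower number from compound 1 to compound 2 (0.14 log units; within the scatter) stays within the scatter, while the step of a 2.7-fold higher number from compound 2 to compound 3 (0.43 log units; beyond the scatter) lies beyond it.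

Compound 4 `O=S(=O)(NCCCNc1nccc(-c2c(-c3cccc(F)c3)nc3sccn23)n1)c1ccc(Cl)cc1` has not yet been measured. It differs from compound 2 in a single place: chloro in place of hydrogen on an aromatic carbon. Within the data shown here, two measured steps bear on this change. The step of a 1.4-fold lower number from compound 1 to compound 2 (0.14 log units; within the scatter) exchanges a methyl for hydrogen on an aromatic carbon and stays within the scatter, so a small substituent change of this kind has so far barely moved the number. The step of a 2.7-fold higher number from compound 2 to compound 3 (0.43 log units; beyond the scatter) brings in the chloro group, but the chain carrying the sulfonyl group is altered at the same time, so the contribution of the chloro group alone cannot be separated out. The step of a 2.0-fold higher number from compound 1 to compound 3 (0.29 log units; within the scatter) combines both changes and also stays within the scatter. A step no larger than the scatter is therefore expected, in either direction. Compound 4 is expected to give 8000 nM in this assay, with a range from 4000 nM to 16000 nM. That amounts to an expected step of a 1.2-fold higher number from compound 2 to compound 4 (0.07 log units; within the scatter).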

Compound 4, half-maximal inhibitory concentration: 8450 nM
Estimate against measurement, compound 4: 1.1-fold (0.02 log units) below, and the stated range covers the measured number.
By their numbers in this assay, from the lowest: compounds 2, 4, 1 and 3 (each within the scatter of the next, the first and the last beyond it).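

In this assay, the chloro group can now be read on its own, with the chain left unchanged: chloro in place of hydrogen on the aromatic carbon gives a 1.2-fold higher number from compound 2 to compound 4 (0.09 log units; within the scatter), and chloro in place of methyl at the same carbon gives a 1.1-fold lower number from compound 1 to compound 4 (0.05 log units; within the scatter), so hydrogen, methyl and chloro at this position cannot be told apart in this assay. With the 4-chlorophenyl group held constant, changing the chain alone gives a 2.2-fold lower number from compound 3 to compound 4 (0.34 log units; beyond the scatter), which lies beyond the scatter, so the chain, rather than the substituent on the aromatic ring, is the single change among these compounds that moves the number beyond the scatter. No measurement shown here explains why either change has the size it does.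

The compounds shown leave open whether a methoxy group, a nitrile or an amine on this same aromatic carbon would also remain within the scatter of hydrogen, methyl and chloro. They also leave open whether a chain longer than that of compound 4 would continue the difference seen between compound 3 and compound 4.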